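Compound 1 to compound 4: methyl on an aromatic carbon

A few compounds are considered here, and "the series" means these few. Any claim that something is new, unique, unknown or untested is made for them only; others in the source may bear on it.

In an ADME assay on microsomes from liver (Rattus norvegicus) for metabolic stability (on this read-out higher numbers stand for fast clearance and lower numbers for slow clearance), compound 1 (`CC(C)Oc1cc(Oc2cnc(C(=O)N(C)C)nc2)cc(-c2nccc(=O)[nH]2)c1`) gives < 25.4 mL/min/kg, which is a limit of the assay and not a number. Its standing on the numbers shown is therefore (the limit of < 25.4 mL/min/kg in this assay, at which 1 of the 3 values shown sits).

Two analogues with other groups on the same oxygen give numbers. Compound 2 (`CCC(CC)Oc1cc(Oc2cnc(C(=O)N(C)C)nc2)cc(-c2nccc(=O)[nH]2)c1`) gives 91 mL/min/kg, and compound 3 (`COC[C@H](C)Oc1cc(Oc2cnc(C(=O)N(C)C)nc2)cc(-c2nccc(=O)[nH]2)c1`) gives 38 mL/min/kg.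

Compound 4 (`Cc1cnc(-c2cc(Oc3cnc(C(=O)N(C)C)nc3)cc(OC(C)C)c2)[nH]c1=O`) keeps the isopropyl of compound 1 and carries one change: methyl in place of hydrogen on an aromatic carbon.

For the measured compounds named here, no measured step touches that carbon, so the evidence is indirect. All three measured steps change the group on the oxygen. The data show an at least 3.5-fold higher number from compound 1 to compound 2 (0.55 log units; beyond the scatter), and this step is beyond the scatter. They also show an at least 1.4-fold higher number from compound 1 to compound 3 (0.17 log units; that floor lies within the scatter), whose floor lies within the scatter, and a 2.4-fold lower number from compound 2 to compound 3 (0.38 log units; beyond the scatter), which is beyond the scatter.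

Only the rise in an at least 3.5-fold higher number from compound 1 to compound 2 (0.55 log units; beyond the scatter) gives a hint for added carbon, and it comes from a different site. A small move towards a higher number is therefore expected, probably not beyond the scatter. The expected step is an at least 1.1-fold higher number from compound 1 to compound 4 (0.04 log units; that floor lies within the scatter). Compound 4 is estimated at 28 mL/min/kg in this assay, with an expected range of 16 mL/min/kg to 52 mL/min/kg.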

Compound 4, clearance: < 25.4 mL/min/kg
Compound 4 ended at the assay's limit; the forecaster's own chance of this, stated with the estimate: 40%; middle value at least 1.1-fold (0.04 log units) away from the limit.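

Compound 4, like compound 1, gives a limit of the assay and not a number in this assay, so the step between them cannot be read: the limit of < 25.4 mL/min/kg in this assay, at which 2 of the 4 values shown sit.

Still open, going by these compounds, is whether methyl in place of hydrogen on that aromatic carbon shifts clearance in this assay at all, in either direction, on a compound that gives a number rather than a limit.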